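The source may hold more compounds than are shown below. What is called first, only, known or untested is meant among the compounds shown, and "the series" means these compounds.

In a functional assay on PC-3 cells (Homo sapiens) for antiproliferative activity, read by MTT assay, with a stated time of 72 h (a lower number here means a stronger inhibitor, a higher number a weaker inhibitor), compound 1 (`CCn1c(C(=O)N[C@H](C(=O)O)C(C)C)ccc1C(CC)(CC)c1ccc(C#CC(O)(CC)CC)c(C)c1`) gives 5000 nM and compound 2 (`CCN(CC)CCNC(=O)c1cc(C(CC)(CC)c2ccc(C#CC(O)(CC)CC)c(C)c2)cn1CC`) gives 5350 nM. Going by the values given here, these two values lie within the scatter of each other, so compound 2 stands level with the only other measured compound. Compound 3 (`CCn1cc(C(CC)(CC)c2ccc(C#CC(O)(CC)CC)c(C)c2)cc1C(=O)N[C@H](C(=O)O)C(C)C`) keeps the core of compound 2 and has 1-carboxy-2-methylpropyl in place of 2-(diethylamino)ethyl on an amide-type nitrogen. Among the compounds with values here, no measured pair isolates this change, so any expectation for it remains tentative. Compound 1 also carries 1-carboxy-2-methylpropyl on an amide-type nitrogen, and compound 1 still gives 5000 nM. On that basis, no step beyond the scatter is expected in this assay, in either direction. The estimated step of a 1.1-fold lower number from compound 2 to compound 3 (0.03 log units; within the scatter) is expected to stay small. For compound 3 the expected value is 5000 nM, with an estimated range from 2000 nM to 12000 nM.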

Compound 3, half-maximal inhibitory concentration: 3750 nM
Beside the measured number, compound 3's estimate is 1.3-fold (0.12 log units) above it, and the stated range covers the measured number.
By their numbers in this assay, from the lowest: compounds 3, 1 and 2 (each within the scatter of the next).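

In this assay, going by these compounds alone, 1-carboxy-2-methylpropyl in place of 2-(diethylamino)ethyl on an amide-type nitrogen gives a 1.4-fold lower number from compound 2 to compound 3 (0.15 log units; within the scatter), and this pair is the first to isolate the change. Swapping one of these two groups for the other at this place therefore produces no step that can be told from the scatter, so this assay does not separate them. No measured information is available that bears on this result.

The compounds shown leave open whether any other group on this nitrogen would produce a step beyond the scatter, such as a methyl ester in place of the carboxylic acid, a longer chain or a simple hydrogen. They also leave open whether the opposite configuration at the defined stereocentre of 1-carboxy-2-methylpropyl would change the number.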